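Amide-side variation in one series: working notes

The compounds below may be only part of what the source reports. "The series", "measured", "known", "first", "only" and "open" are said of these compounds alone.

Measured so far:
compound 1, `C[C@H](C(=O)N1CCCCC1)N1CCN(S(=O)(=O)c2ccc(C(C)(C)C)cc2)CC1`: > 40000 nM
compound 2, `CC(C(=O)N1CCC(F)(F)CC1)N1CCN(S(=O)(=O)c2ccc(C(C)(C)C)cc2)CC1`: > 40000 nM

Both compounds were tested in an ADME assay on HepG2 cells (Homo sapiens) for inhibition, with a stated time of 48 h; a higher number here means that more compound is needed for the effect, a lower number that less compound is needed. Compound 1 gives > 40000 nM, which is a limit of the assay and not a number. Compound 2 gives > 40000 nM, again a limit rather than a number. Among the compounds with values here, both results sit at the limit of > 40000 nM in this assay, at which 2 of the 2 values shown sit, so compound 2 stands nowhere on a numerical scale here; only a limit is known for it, and the one other value shown is a limit as well. Within the data shown here, no pair of measured compounds differing in one place exists, so no measured step is available.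

Compound 3, `CC(C(=O)N1Cc2ccccc2C1)N1CCN(S(=O)(=O)c2ccc(C(C)(C)C)cc2)CC1`, remains to be measured. It differs from compound 2 by a group of 9 heavy atoms (8 carbon, 1 nitrogen; one five-membered non-aromatic ring with 1 hetero atom, one six-membered aromatic ring of carbon only) in place of a group of 8 heavy atoms (5 carbon, 1 nitrogen, 2 fluorine; one six-membered non-aromatic ring with 1 hetero atom), on a carbonyl carbon. Among the measured compounds shown here, with no measured step to lean on and both known results at the limit, no step beyond the scatter is expected in either direction; the outcome for compound 3 is expected to be a further limit, or at best a number close to it. The expected step from compound 2 to compound 3 is a step that the limit leaves unreadable from compound 2 to compound 3. Compound 3 is estimated at 60000 nM, within 20000 nM to 200000 nM.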

Compound 3, half-maximal effective concentration: > 40000 nM
Compound 3: no number, only a limit; the forecaster's own chance of this, stated with the estimate: 75%; the middle value lies beyond the limit too.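

In this assay compound 3 gives > 40000 nM, which is a limit of the assay and not a number. No step from compound 2 to compound 3 can be read, as both results are limits: the limit of > 40000 nM in this assay, at which 3 of the 3 values shown sit.

The compounds shown leave open whether any amide-side group in this series gives a number in this assay, and how compound 1, compound 2 and compound 3 would rank.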